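The compounds below may be only part of what the source reports. "The series", "measured", "known", "first", "only" and "open" are said of these compounds alone.

Of the compounds shown here, three of a shared core have been tested in an ADME assay on Raji cells (Homo sapiens) for cytotoxicity, read by CellTiter-Glo and resazurin assay, with a stated time of 72 h; a higher number here means that more compound is needed for the effect, a lower number that less compound is needed. In this assay compound 1, with structure `CC(C)Oc1cccc(-c2ccc(C(=O)N(Cc3cccc(OCCCCCC(=O)O)c3)C(C)C)cc2)c1`, reaches only a limit of the assay, recorded as > 26000 nM. Compound 2, with structure `COc1cccc(-c2ccc(C(=O)N(Cc3cccc(OCCCCCC(=O)O)c3)C(C)C)cc2)c1`, likewise gives only a limit, > 20900 nM. Compound 3, with structure `CC(C)N(Cc1cccc(OCCCCCC(=O)O)c1)C(=O)c1ccc(-c2cccc(O)c2)cc1`, also stands at a limit of the assay, > 26000 nM. Because every measured value is a limit, the steps among them cannot be read: a step that the two limits leave unreadable from compound 1 to compound 2, a step that the two limits leave unreadable from compound 1 to compound 3 and a step that the two limits leave unreadable from compound 2 to compound 3 all remain of unknown size. Among the compounds with values here, the only evidence is the limit of > 20900 nM in this assay, at which 1 of the 3 values shown sits, and (the limit of > 26000 nM in this assay, at which 2 of the 3 values shown sit).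

Compound 4, with structure `COc1ccc(F)c(-c2ccc(C(=O)N(Cc3cccc(OCCCCCC(=O)O)c3)C(C)C)cc2)c1`, is not yet measured. It differs from compound 3 by 2-fluoro-5-methoxyphenyl in place of 3-hydroxyphenyl on an aromatic carbon. Within the data shown here, none of the measured steps bears on this change in a readable way, since all three compounds sit at limits. The expectation is therefore that compound 4 will also show no measurable effect within the tested range, with the step from compound 3 to compound 4 expected to be a step that the limit leaves unreadable from compound 3 to compound 4. Compound 4 is estimated at 30000 nM, within a range from 10000 nM to 100000 nM, most likely reported again as a limit.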

Compound 4, half-maximal effective concentration: > 26000 nM
Compound 4: only a limit was reported; the forecaster's own chance of this, stated with the estimate: 85%; the middle value is on the limit's open side.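

In this assay compound 4 gives only a limit, > 26000 nM. Compound 1, compound 2 and compound 3 also stand at limits, and the steps linking them to compound 4 cannot be read. The compounds shown leave open at what concentration any of them reaches the half-maximal effect, and whether any change here, including fluoro in place of hydrogen, shifts that concentration.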